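A few compounds are considered here, and "the series" means these few. Any claim that something is new, unique, unknown or untested is made for them only; others in the source may bear on it.

Values in a physicochemical assay for solubility, at pH 7.4 (on this read-out lower numbers stand for lower solubility and higher numbers for higher solubility), for the series so far:
- compound 1 `CC(=O)c1ccc(NC(=O)Nc2cc(C)nc3ccccc23)cc1` (3800 nM)
- compound 2 `COC(=O)c1ccc(NC(=O)Nc2cc(C)nc3ccccc23)cc1` (1200 nM)
- compound 3 `Cc1cc(NC(=O)Nc2ccc(C(N)=O)cc2)c2ccccc2n1` (900 nM)

On these numbers compound 3 (900 nM) sits at the low end with compound 2 (1200 nM), the two lying within the scatter of each other, and compound 1 stands clear of both.

The next step leads to compound 4 `Cc1cc(NC(=O)Nc2ccc(O)cc2)c2ccccc2n1` and reads hydroxy in place of carbamoyl on an aromatic carbon in that hydroxy takes the place of carbamoyl on an aromatic carbon. Within the data shown here, no measured step makes this exchange. The closest evidence is the set of changes on the carbonyl carbon: a 3.2-fold lower number from compound 1 to compound 2 (0.50 log units; beyond the scatter) and a 4.2-fold lower number from compound 1 to compound 3 (0.63 log units; beyond the scatter) are modest, while a 1.3-fold lower number from compound 2 to compound 3 (0.12 log units; within the scatter) stays within the scatter. All three keep the carbonyl, which compound 4 loses, so they guide the size of the step better than its direction.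

A modest step is expected in this assay, and upward only tentatively, since compound 3 shares the low end of a small range. Among the measured compounds shown here, the expected move is a 2.2-fold higher number from compound 3 to compound 4 (0.35 log units; beyond the scatter) and no larger than the biggest step so far. For compound 4 the estimated value is 2000 nM with an expected range from 600 nM to 6000 nM.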

Compound 4, solubility: 100 nM
For compound 4 the middle estimate is 20-fold (1.30 log units) above the measured one, outside the stated range (below it).
By their numbers in this assay, from the lowest: compound 4; then compounds 3 and 2 (each within the scatter of the next); then compound 1.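

At this position, on an aromatic carbon para to a large group, hydroxy gives the lowest number of the series in this assay (a 9.0-fold lower number from compound 3 to compound 4 (0.95 log units; beyond the scatter); a 12-fold lower number from compound 2 to compound 4 (1.08 log units; beyond the scatter); a 38-fold lower number from compound 1 to compound 4 (1.58 log units; beyond the scatter)), and each of these steps is larger than any step among compounds 1, 2 and 3. Exchanges among acetyl, methoxycarbonyl and carbamoyl had moved the number far less, so removing the carbonyl from this position goes with a larger change than varying what is attached to it, with no compound of the four going against this. Carbamoyl and hydroxy carry the same counts of hydrogen-bond donors and acceptors, so those counts do not separate compound 3 from compound 4, while the group shrinks from 3 heavy atoms to 1.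

As far as these compounds go, whether the low number belongs to hydroxy itself or simply to the absence of a carbonyl stays open, and an amine or a carboxylic acid at this position would help to separate the two. Nothing available here bears on why the number falls so far with this change.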